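A few compounds are considered here, and "the series" means these few. Any claim that something is new, unique, unknown or untested is made for them only; others in the source may bear on it.

Of the compounds shown here, three built on one shared core have been tested in an assay for inhibition of MAP kinase-interacting serine/threonine-protein kinase 1 (Homo sapiens), read by luminescence and ADP-Glo, with a stated time of 2 h; on this read-out higher numbers stand for weaker inhibition and lower numbers for stronger inhibition. Compound 1 `NC(=O)c1ccc(Cn2cc(-c3ccc4cn[nH]c4c3)ccc2=O)cc1` reaches only the limit of the assay, > 2000 nM, so no number is known for it; the limit of > 2000 nM in this assay, at which 1 of the 3 values shown sits, describes this. Compound 2 `Nc1n[nH]c2cc(-c3ccc(=O)n(Cc4cccc(Cl)c4)c3)ccc12` gives 11 nM. Compound 3 `O=c1ccc(-c2ccc3cn[nH]c3c2)cn1Cc1cccc(C(F)(F)F)c1` gives 40 nM, the highest of the two numbers obtained; its nearest neighbour is compound 2, which lies a distance below it that is beyond the usual scatter. Compound 3 and compound 2 differ in more than one place, so no single step can be read between them.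

Compound 4 `O=c1ccc(-c2ccc3cn[nH]c3c2)cn1Cc1cccc(F)c1` has not been measured. It differs from compound 3 in one place: fluoro in place of trifluoromethyl on an aromatic carbon. Both the group that leaves and the group that enters are without hydrogen-bond donors or acceptors and carry no charge. Among the measured compounds shown here, no measured pair here differs in just this way, so the expectation rests on caution alone: the step from compound 3 to compound 4 is estimated at a 1.3-fold higher number from compound 3 to compound 4 (0.10 log units; within the scatter), that is, no change beyond the scatter in either direction. Compound 4 is expected to give about 50 nM in this assay, within a range from 15 nM to 200 nM.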

Compound 4, half-maximal inhibitory concentration: 74 nM
Estimate against measurement, compound 4: 1.5-fold (0.17 log units) below; the measured number falls inside the stated range.
By their numbers in this assay, from the lowest: compound 2; then compounds 3 and 4 (each within the scatter of the next). At a limit, above all of these: compound 1.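

Among the compounds shown here, the first step that can be read in this assay is a 1.9-fold higher number from compound 3 to compound 4 (0.27 log units; within the scatter), with fluoro in place of trifluoromethyl on an aromatic carbon. At this place, on a six-membered aromatic ring of carbon only and meta to a large group, a group of 4 heavy atoms and a group of 1 heavy atom therefore give numbers that cannot be told apart, so this one change does not separate the two compounds on this read-out. Nothing measured here gives a reason for this result.

The compounds shown leave open whether a quite different group on this aromatic carbon, such as a carboxylic acid or a methoxy group, would also stay within the scatter of these two compounds, since both groups compared here are without hydrogen-bond donors or acceptors and carry no charge. For the compounds shown here, compound 1 and compound 2 each differ from compound 3 and compound 4 in more than one place, so no step to them can be read, and what each of their differences contributes stays unknown.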